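A few compounds are considered here, and "the series" means these few. Any claim that something is new, unique, unknown or untested is made for them only; others in the source may bear on it.

Compound 1 `CC1(C)CCC(C)(C)c2cc(-c3ccc4cc(C(=O)O)ccc4c3)ccc21` is the stronger of the two measured compounds in an assay on isolated protein with cellular retinoic acid-binding protein 1 (Gallus gallus) as the target (a lower number here means a stronger inhibitor, a higher number a weaker inhibitor), where compound 1 gives 1.6 uM. Among the measured compounds shown here, its only measured neighbour is compound 2 `Cc1cc2c(cc1-c1ccc3cc(C(=O)O)ccc3c1)C(C)(C)CCC2(C)C`, for which this assay gives 4.8 uM; the change from compound 1 to compound 2 is a 3.0-fold higher number from compound 1 to compound 2 (0.48 log units; beyond the scatter), and that step lies beyond the scatter.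

Compound 3 `Cc1c(-c2ccc3c(c2)C(C)(C)CCC3(C)C)ccc2cc(C(=O)O)ccc12` is reached from compound 1 by a change of the same kind but on the other ring system: methyl in place of hydrogen on an aromatic carbon, placed ortho to a fused ring, ortho to a large group and meta to a fused ring. For the measured compounds named here, the one step that bears on it, the change from compound 1 to compound 2 in this assay, added a methyl on an aromatic carbon and weakened binding modestly. On that basis compound 3 is expected to be somewhat weaker than compound 1 in this assay, with an estimated step of a 2.5-fold higher number from compound 1 to compound 3 (0.40 log units; beyond the scatter). The estimate for compound 3 in this assay is 4 uM, with a range from 1.6 uM to 10 uM.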

Compound 3, concentration for 50% inhibition: 15 uM
Beside the measured number, compound 3's estimate is 3.8-fold (0.57 log units) below it; the whole stated range lies below it.
By their numbers in this assay, from the lowest: compound 1; then compound 2; then compound 3.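

In this assay the methyl in place of hydrogen, ortho to a fused ring, ortho to a large group and meta to a fused ring, gives a 9.4-fold higher number from compound 1 to compound 3 (0.97 log units; beyond the scatter) and so costs more binding than the earlier step suggested. Set beside a 3.0-fold higher number from compound 1 to compound 2 (0.48 log units; beyond the scatter) on the other ring system, it shows that the same replacement raises the number in both places but not by one shared amount, so the size of the step depends on where the methyl stands on the core of compound 1. Nothing available explains why this position gives the larger step.

Going by these compounds, it remains open whether a fluorine, a methoxy or an ethyl at this same carbon would give a similar step. The compounds shown also leave open whether a hydroxyl there would weaken binding at all.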